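From a fluorophenyl to a phenethyl arm on the core

The source may report more compounds than this note shows. Statements on the series, on what has been measured and on what is new or still open speak of the compounds shown alone.

Compound 2 `C=C(Br)C(=O)Nc1cccc(-c2cn3nc(-c4ccc(F)cc4)sc3n2)c1` holds the lowest of the three numbers gathered so far in a functional assay on FM3A cells (Mus musculus) for inhibition, read by cell counting, with a stated time of 2 days; a higher number here means a weaker inhibitor, a lower number a stronger inhibitor: compound 2 gives 610 nM. Compound 1 `CCc1ccc(-c2nn3cc(-c4cccc(N)c4)nc3s2)cc1` comes nearest, and in this assay compound 1 gives 8200 nM, a gap that lies beyond the scatter. Compound 3 `COc1ccc(-c2nn3cc(-c4cccc(N)c4)nc3s2)cc1OC` lies furthest away, and in this assay compound 3 gives 13000 nM, again beyond the scatter. Both compound 1 and compound 3 differ from compound 2 in more than one place, so their numbers say nothing about any single change on the shared core.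

Compound 4 `C=C(Br)C(=O)Nc1cccc(-c2cn3nc(CCc4ccccc4)sc3n2)c1` has not yet been measured. It differs from compound 2 in one place only: phenethyl in place of 4-fluorophenyl on an aromatic carbon. Within the data shown here, no pair of measured compounds shows a change of this kind, so the size of the step cannot be read from the data. The estimated step is a 2.5-fold higher number from compound 2 to compound 4 (0.39 log units; beyond the scatter), a modest weakening somewhat beyond the scatter. Compound 4 is therefore expected to give 1500 nM in this assay, with a range from 400 nM to 6000 nM.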

Compound 4, half-maximal inhibitory concentration: 2600 nM
The estimate for compound 4 lay 1.7-fold (0.24 log units) below the measured number, within the range that was stated.
By their numbers in this assay, from the lowest: compound 2; then compound 4; then compounds 1 and 3 (each within the scatter of the next).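

In this assay, among these compounds, this pair gives the first reading of a single change at this position: a 4.3-fold higher number from compound 2 to compound 4 (0.63 log units; beyond the scatter), so the phenethyl arm is a modest step away from the 4-fluorophenyl. The change both removes the fluorine and adds a chain carrying the ring, and this one step cannot separate the two. No measurement at hand explains the size of the step.

Going by these compounds, whether a plain phenyl or a benzyl group on this aromatic carbon would give a number closer to that of compound 2 stays open, and that comparison would begin to separate the loss of the fluorine from the addition of the chain. Also open, on these data alone, is how a longer chain, or an amine or a carboxylic acid on the ring of the arm, would shift the number.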